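This account rests on a few compounds, and the source may have more. Where it says the series, first, only, none or still open, it means among the compounds named here.

Measured compounds:
Compound 1, `O=C(Nc1ccc(OC(F)(F)F)cc1)NC1CCN(C(=O)c2ccoc2)CC1`, gives 3.63.
Compound 2, `CC[C@H](C)C(=O)N1CCC(NC(=O)Nc2ccc(C(F)(F)F)cn2)CC1`, gives 3.22.
Compound 3, `CCOC(=O)N1CCC(NC(=O)Nc2ccc(C(F)(F)F)c(F)c2)CC1`, gives 5.46.

These three values come from a physicochemical assay for lipophilicity, read by HPLC, with a stated time of 90 min, tested at 100 uM; a lower number here means a more polar compound, a higher number a more lipophilic compound. Among them compound 1 stands second highest. Its nearest neighbour is compound 2, whose value lies lower by a gap that is beyond the usual scatter of repeated measurements. Its furthest neighbour is compound 3, whose value lies higher by a much wider gap, also well beyond the scatter. No two of the measured compounds differ in only one place, so none of these gaps can be tied to a single structural change.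

Compound 4, `O=C(Nc1ccc(OC(F)(F)F)cc1)NC1CCN(C(=O)C2CCOCC2)CC1`, has not yet been measured in this assay. It differs from compound 1 in one place: oxan-4-yl in place of furan-3-yl on a carbonyl carbon. Within the data shown here, since no measured pair isolates this change, the size of the step has to be estimated rather than read off. A small step downward is expected here, one that may not reach beyond the scatter; the expected step is a number 0.33 log units lower from compound 1 to compound 4 (beyond the scatter). Compound 4 is therefore estimated at 3.3 in this assay, with a likely range from 2.8 to 3.8.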

Compound 4, partition coefficient: 3.26
For compound 4 the middle estimate is 0.04 log units above the measured one; the measured number falls inside the stated range.
By their numbers in this assay, from the lowest: compounds 2 and 4 (each within the scatter of the next); then compound 1; then compound 3.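

In this assay, the position on a carbonyl carbon whose other neighbour is an amide-type nitrogen in a ring now has its first comparison in which only one place differs: oxan-4-yl in place of furan-3-yl gives a number 0.37 log units lower from compound 1 to compound 4 (beyond the scatter). The read-out at this position therefore responds to a change that leaves the hydrogen-bond donor and acceptor counts of the group the same, while a five-membered aromatic ring with 5 heavy atoms gives way to a six-membered non-aromatic ring with 6. Nothing at hand bears on why the number moves, so the shares of ring size and aromatic character in this step remain unknown.

As far as these compounds go, compounds 2 and 3 differ from compound 4 in more than one place, so no further step can be read, and it stays open whether the same change would give a similar step on another core. Also open, from the compounds shown here alone, is how the read-out would respond at this position to cyclohexyl, which has a six-membered ring without the oxygen, or to a group carrying an amine.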